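Methoxy added to compound 3: expected inhibition

The source may hold more compounds than are shown below. What is called first, only, known or untested is meant among the compounds shown, and "the series" means these compounds.

In an assay on isolated protein for inhibition of vascular endothelial growth factor receptor 1 (Homo sapiens), read by ELISA, with a stated time of 20 min, tested at 1 uM (a lower number here means less inhibition, a higher number more inhibition at the concentration tested (going by the name of the read-out)), compound 3 `OB(O)c1ccc2ncnc(Nc3cccc(Cl)c3)c2c1` gives 7%, the only figure in the set, and a low one. Compound 1 `COc1cc2ncnc(Nc3cccc(Cl)c3)c2cc1B1OC(C)(C)C(C)(C)O1` is reported in this assay as "not active" (no number reported), and compound 2 `COc1cc2ncnc(Nc3ccc(F)c(Cl)c3)c2cc1B(O)O` as "not active" (no number reported); neither carries a number, so compound 3 stands as the sole quantified entry. Compound 4 `COc1cc2ncnc(Nc3cccc(Cl)c3)c2cc1B(O)O` differs from compound 3 by methoxy in place of hydrogen on an aromatic carbon. For the measured compounds named here, no step between two measured compounds is available to size this change. That compound 1 shows "not active" (no number reported) and compound 2 shows "not active" (no number reported), both with the methoxy in place, argues against a gain. The step is expected to be small, a number 2 percentage points lower from compound 3 to compound 4 (within the scatter), within the scatter or slightly downward. Compound 4 is estimated at 5%, range 0% to 15%, with a fair chance of being reported without a number.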

Compound 4, a percentage reported as inhibition, at one concentration (the size of the read-out at that concentration, not a potency): "not active" (no number reported)
For compound 4 the study gives words and no number; there is nothing to compare the estimate with.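

For the compounds shown here, compound 4 is reported in words only in this assay, so no step from compound 3 can be read. On these data alone, how far methoxy in place of hydrogen shifts inhibition stays open. No measured evidence bears on this result.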